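The source may report more compounds than this note shows. Statements on the series, on what has been measured and on what is new or still open speak of the compounds shown alone.

Compound 2, `Cc1ccc2[nH]c(=O)c(CN(Cc3ccc(OCC(=O)OC(C)(C)C)cc3)Cc3ccc(C(C)(C)C)cc3)cc2c1`, is one of two compounds already tested in a toxicity assay on MDCK cells (Canis lupus familiaris) for cytotoxicity, read by crystal violet staining, with a stated time of 48 h; on this read-out lower numbers stand for higher toxicity in this test and higher numbers for lower toxicity in this test. In this assay compound 2 gives > 10000 nM, which is a limit of the assay rather than a number. Compound 1, `Cc1ccc2[nH]c(=O)c(CN(Cc3ccccc3)Cc3ccc(C(C)(C)C)cc3)cc2c1`, shares the same core; in this assay compound 1 gives > 5000 nM, which is likewise a limit. Going by the values given here, the single measured step, a step that the two limits leave unreadable from compound 1 to compound 2, is thus not readable in size, and the limit of > 10000 nM in this assay, at which 1 of the 2 values shown sits, together with the limit of > 5000 nM in this assay, at which 1 of the 2 values shown sits, shows that both values sit at limits. Compound 3, `CCOc1ccc(CN(Cc2ccc(C(C)(C)C)cc2)Cc2cc3cc(C)ccc3[nH]c2=O)cc1`, differs from compound 2 by methyl in place of tert-butoxycarbonyl on a saturated chain carbon bound to an oxygen on an aromatic ring. Among the compounds with values here, no measured step touches this change, and with both known values being limits no step beyond the scatter is expected in this assay; the expected step is a step that the limit leaves unreadable from compound 2 to compound 3. Compound 3 is therefore estimated at about 15000 nM, within a range from 5000 nM to 50000 nM, most probably reported again only as a limit.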

Compound 3, half-maximal cytotoxic concentration: > 10000 nM
Compound 3: only a limit was reported; the forecaster's own chance of this, stated with the estimate: 80%; the middle value lies beyond the limit too.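

Going by these compounds alone, compound 1, compound 2 and compound 3 are all reported only as limits in this assay, so no step among them can be read. The compounds shown leave open at what concentration each becomes toxic to the cells, and whether the differing groups change that concentration at all.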